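The compounds below may be only part of what the source reports. "The series", "measured", "known", "first", "only" and "open" are said of these compounds alone.

Notes on the series. The shared core carries an exocyclic nitrogen whose substituent is varied. Compound 1 is `Nc1ncc(-c2ccc(O)c(Cl)c2)c(-c2ccccc2)n1`, compound 2 is `CCCC(=O)Nc1ncc(-c2cccc(Cl)c2)c(-c2ccccc2)n1`, and compound 3, not yet measured, is `C#CCNc1ncc(-c2cccc(Cl)c2)c(-c2ccccc2)n1`.

In an assay on CHO cells for displacement of a labelled ligand from adenosine receptor A1 (Homo sapiens), read by scintillation counting, with a stated time of 1 h, tested at 1 uM (a lower number here means less inhibition, a higher number more inhibition at the concentration tested (going by the name of the read-out)), compound 1 gives > 80%, which is a limit of the assay and not a number. Compound 2 gives > 80% in this assay, likewise a limit rather than a number. Where compound 2 stands is therefore fixed only by the limit of > 80% in this assay, at which 2 of the 2 values shown sit. Among the compounds with values here, no pair of measured compounds differing in a single place is available, so no step size can be read from the data.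

The change from compound 2 to compound 3 is propargyl in place of propylcarbonyl on a nitrogen on an aromatic ring. Because the limit of > 80% in this assay, at which 2 of the 2 values shown sit, holds with the nitrogen unsubstituted in compound 1 as well as with propylcarbonyl on it in compound 2, a third small substituent there is expected to leave the displacement close to the limit. The step of a number at least 2 percentage points lower from compound 2 to compound 3 (that floor lies within the scatter) is expected to be none beyond the scatter, with a downward drift the more likely direction if any. Compound 3 is accordingly expected to give 78% in this assay, in the range 55% to 95%.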

Compound 3, a percentage reported as inhibition, at one concentration (the size of the read-out at that concentration, not a potency): 76%
Compound 3: the middle estimate sits 2 percentage points above what was measured, and the stated range covers the measured number.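

Notes on the result. With propargyl in place of propylcarbonyl on a nitrogen on an aromatic ring, this assay gives a number at least 4 percentage points lower from compound 2 to compound 3 (that floor lies within the scatter), so this nitrogen can carry a substituent with no carbonyl and the displacement remains substantial at the concentration tested. Within the data shown here, compound 3 gives 76%, the only value shown that is a number and not a limit, and this gives further changes at this nitrogen a fixed point of comparison. Going by these compounds, the true size of the step stays unknown because compound 2 is held only by a limit: the limit of > 80% in this assay, at which 2 of the 3 values shown sit.

The compounds shown leave open how an amine, a carboxylic acid or a longer chain on this nitrogen would read in this assay, and whether an amide with a shorter or a branched chain would stay at the limit seen for compound 2. Also open, on these data alone, is whether the change from propylcarbonyl to propargyl would read the same way on a core carrying the hydroxy and chloro substituents of compound 1.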